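Swapping a Pyrrole for a Methoxypyridine on the Hydrazone

The source may report more compounds than this note shows. Statements on the series, on what has been measured and on what is new or still open speak of the compounds shown alone.

Of the compounds shown here, three sharing one core have been measured in an assay on CHO-K1 cells for displacement of a labelled ligand from adenosine receptor A1 (Homo sapiens), read by scintillation counting, with a stated time of 60 min; on this read-out higher numbers stand for weaker inhibition and lower numbers for stronger inhibition. Compound 3 `Nc1nc(N/N=C/c2ccc[nH]2)nc2c1ncn2[C@@H]1O[C@H](CO)[C@@H](O)[C@H]1O` gives 8 nM, the lowest number of the three. Compound 1 `Nc1nc(N/N=C/c2cccc(OCc3ccccc3)c2)nc2c1ncn2[C@@H]1O[C@H](CO)[C@@H](O)[C@H]1O` gives 13 nM in this assay, which lies within the scatter of compound 3, so the two cannot be ranked. Compound 2 `COc1cc(/C=N/Nc2nc(N)c3ncn([C@@H]4O[C@H](CO)[C@@H](O)[C@H]4O)c3n2)ccc1OCc1ccccc1` gives 9140 nM in this assay, far beyond the scatter of compound 3 and the highest number of the set.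

Compound 4 `COc1ccc(/C=N/Nc2nc(N)c3ncn([C@@H]4O[C@H](CO)[C@@H](O)[C@H]4O)c3n2)cn1` has not yet been measured. It differs from compound 3 in one place: 6-methoxypyridin-3-yl in place of 1H-pyrrol-2-yl on a carbon with a double bond to nitrogen. Going by the values given here, no measured pair shows this exact change, so the size of the step is uncertain. The expected step in this assay is a 13-fold higher number from compound 3 to compound 4 (1.10 log units; beyond the scatter), towards weaker inhibition. Compound 4 is expected to give about 100 nM in this assay, within a range of 15 nM to 1500 nM.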

Compound 4, inhibition constant: 2.6 nM
For compound 4 the middle estimate is 38-fold (1.59 log units) above the measured one; the measured number lies below the stated range.
By their numbers in this assay, from the lowest: compound 4; then compounds 3 and 1 (each within the scatter of the next); then compound 2.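

In this assay, the step from the pyrrole to the methoxypyridine is a 3.1-fold lower number from compound 3 to compound 4 (0.49 log units; beyond the scatter), so this position on the carbon with a double bond to nitrogen tolerates the larger 6-methoxypyridin-3-yl group. The 1H-pyrrol-2-yl hydrogen-bond donor is also not required for a low number, as compound 4 lacks it. Nothing available explains the step.

Going by these compounds, whether the step belongs to the methoxy group or to the pyridine ring stays open. A phenyl ring or an unsubstituted pyridine ring on the same carbon would separate the two.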